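Difluorophenyl in Place of Aminophenyl: an Expected Shift

The compounds below may be only part of what the source reports. "The series", "measured", "known", "first", "only" and "open" are said of these compounds alone.

Compound 1 `COc1cc(-c2cc(/C=C/C(=O)c3ccc(N)cc3)[nH]n2)cc(OC)c1OC`: 56%
Compound 2 `COc1cc(-c2cc(/C=C/C(=O)c3ccc(Cl)c(Cl)c3)[nH]n2)cc(OC)c1OC`: 80%
Compound 3 `COc1ccc(C(=O)/C=C/c2cc(-c3cc(OC)c(OC)c(OC)c3)n[nH]2)cc1OC`: 47%

In a functional assay on HCT-116 cells (Homo sapiens) for cytotoxicity, read by sulforhodamine B assay, with a stated time of 48 h, tested at 1 uM (on this read-out higher numbers stand for a weaker effect at the one concentration tested and lower numbers for a stronger effect), compound 1 stands second highest of the three numbers, with compound 3 at 47% lying within the scatter and compound 2 at 80% set apart. The unmeasured compound 4 `COc1cc(-c2cc(/C=C/C(=O)c3ccc(F)c(F)c3)[nH]n2)cc(OC)c1OC` differs from compound 1 in one place: 3,4-difluorophenyl in place of 4-aminophenyl on a carbonyl carbon. Within the data shown here, the step that bears most on this change is the one to the dichlorophenyl analogue, a number 24 percentage points higher from compound 1 to compound 2 (beyond the scatter), whereas the dimethoxyphenyl step, a number 9 percentage points lower from compound 1 to compound 3 (within the scatter), stayed inside the scatter. Since the entering group shares two ring halogens with compound 2, a modest rise in this assay is expected, a number 14 percentage points higher from compound 1 to compound 4 (beyond the scatter). Compound 4 is therefore estimated at 70%, between 52% and 88%.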

Compound 4, a percentage reported as activity, at one concentration (the size of the read-out at that concentration, not a potency): 113%
The estimate for compound 4 lay 43 percentage points below the measured number; the whole stated range lies below it.
By their numbers in this assay, from the lowest: compounds 3 and 1 (each within the scatter of the next); then compound 2; then compound 4.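

In this assay, the 3,4-difluorophenyl group on the carbonyl carbon gives the weakest effect of the four compounds, with a number 57 percentage points higher from compound 1 to compound 4 (beyond the scatter) and a number 66 percentage points higher from compound 3 to compound 4 (beyond the scatter). Two ring halogens therefore do not guarantee a similar read-out here, since exchanging chlorine for fluorine alone gives a number 33 percentage points higher from compound 2 to compound 4 (beyond the scatter). Nothing available explains this gap. Still open, going by these compounds, is whether a plain phenyl or a 4-chlorophenyl group on the carbonyl carbon would read closer to compound 2 or to compound 4.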